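A fluorophenyl triazole and its expected cytotoxicity

A few compounds are considered here, and "the series" means these few. Any claim that something is new, unique, unknown or untested is made for them only; others in the source may bear on it.

Compound 3 `COc1nc2ccc(Br)cc2cc1C(c1ccccc1)n1cc(CCO)nn1` gives 4.54% in an ADME assay on HEK293 cells (Homo sapiens) for cytotoxicity, read by sulforhodamine B assay, with a stated time of 48 h, tested at 10 uM (on this read-out lower numbers stand for less inhibition and higher numbers for more inhibition at the one concentration tested (going by the name of the read-out)), the lowest of the three numbers shown. Compound 1 `COc1nc2ccc(Br)cc2cc1C(c1ccccc1)n1cc(-c2ccc(Br)cc2)nn1` gives 6.28%, and the step is a number 1.7 percentage points lower from compound 1 to compound 3 (within the scatter). Compound 2 `COc1nc2ccc(Br)cc2cc1C(c1ccccc1)n1cc(CCCO)nn1` gives 27.4%, so that a number 22.9 percentage points lower from compound 2 to compound 3 (beyond the scatter). Compound 4 `COc1nc2ccc(Br)cc2cc1C(c1ccccc1)n1cc(-c2cccc(F)c2)nn1` differs from compound 3 by 3-fluorophenyl in place of 2-hydroxyethyl on an aromatic carbon. The step that bears on this change is a number 1.7 percentage points lower from compound 1 to compound 3 (within the scatter), where a 4-bromophenyl was exchanged for a 2-hydroxyethyl on the same aromatic carbon and the number hardly moved. Putting a 3-fluorophenyl on that aromatic carbon of compound 3 is therefore expected to give a step of a number 1.5 percentage points higher from compound 3 to compound 4 (within the scatter), within the scatter. Compound 4 is estimated at 6%, with a range from 0% to 18%.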

Compound 4, a percentage reported as inhibition, at one concentration (the size of the read-out at that concentration, not a potency): 6.84%
For compound 4 the middle estimate is 0.8 percentage points below the measured one, within the range that was stated.
By their numbers in this assay, from the lowest: compounds 3, 1 and 4 (each within the scatter of the next); then compound 2.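

In this assay the 3-fluorophenyl group on this aromatic carbon reads like the 2-hydroxyethyl group, with a number 2.3 percentage points higher from compound 3 to compound 4 (within the scatter) and like the 4-bromophenyl group, with a number 0.6 percentage points higher from compound 1 to compound 4 (within the scatter), while the 3-hydroxypropyl group stands apart, with a number 20.6 percentage points lower from compound 2 to compound 4 (beyond the scatter). A ring on this carbon therefore does not by itself set the number: ring-free 2-hydroxyethyl sits with both aryl groups, and ring-free 3-hydroxypropyl is the exception. Nothing available explains the separate position of compound 2. From the compounds shown here alone, whether a longer chain or a chain ending in an amine would read like compound 2 stays open.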